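Methoxy in place of trifluoromethyl in a small series

The source may hold more compounds than are shown below. What is called first, only, known or untested is meant among the compounds shown, and "the series" means these compounds.

Measured in a functional assay on PC-9 cells (Homo sapiens) for inhibition, read by MTT assay, with a stated time of 72 h; on this read-out higher numbers stand for weaker inhibition and lower numbers for stronger inhibition:
- compound 1 `Cc1cc(Nc2cc(-c3ccccc3)[nH]n2)n2nc(SCc3ccc(Cl)cc3)nc2n1`: 6710 nM
- compound 2 `Cc1cc(Nc2cc(-c3ccccc3)[nH]n2)n2nc(SCc3ccc(C(F)(F)F)cc3)nc2n1`: 4240 nM

Only these two values are available so far, and compound 2, at 4240 nM, cannot be told apart from compound 1. Compound 3 `COc1ccc(CSc2nc3nc(C)cc(Nc4cc(-c5ccccc5)[nH]n4)n3n2)cc1` has not yet been measured. It carries methoxy in place of trifluoromethyl on an aromatic carbon, para to a large group: methoxy in place of trifluoromethyl on an aromatic carbon. Within the data shown here, one measured step bears on this aromatic carbon: a 1.6-fold lower number from compound 1 to compound 2 (0.20 log units; within the scatter), with trifluoromethyl in place of chloro. Methoxy itself has no measured value in this series, so this evidence is thin. Among the measured compounds shown here, with only that small step to go on, no change beyond the scatter is expected in this assay, in either direction. The expected result is a 1.2-fold higher number from compound 2 to compound 3 (0.07 log units; within the scatter). For compound 3 the estimated value is 5000 nM, with an expected range of 2000 nM to 12000 nM.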

Compound 3, half-maximal inhibitory concentration: 8110 nM
For compound 3 the middle estimate is 1.6-fold (0.21 log units) below the measured one; measured number inside the range.
By their numbers in this assay, from the lowest: compounds 2, 1 and 3 (each within the scatter of the next).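

In this assay, methoxy on this aromatic carbon gives a 1.9-fold higher number from compound 2 to compound 3 (0.28 log units; within the scatter), and against chloro it gives a 1.2-fold higher number from compound 1 to compound 3 (0.08 log units; within the scatter). Chloro, trifluoromethyl and methoxy therefore cannot be told apart at this position in this read-out, even though methoxy brings in a hydrogen-bond acceptor that trifluoromethyl lacks and the earlier compounds offered no such comparison. No available evidence bears on why these three groups read alike.

The compounds shown leave open whether an amine, a carboxylic acid or a longer chain on this aromatic carbon would give a step beyond the scatter. They also leave open whether the same insensitivity would hold if the shared core were changed elsewhere, since all three compounds carry it unaltered.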